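Two Chlorines Join the Carboxyphenyl Sulfonamide

The compounds below may be only part of what the source reports. "The series", "measured", "known", "first", "only" and "open" are said of these compounds alone.

Compound 1, `COc1cc2nc(N3CCN(S(=O)(=O)c4ccc(I)cc4)CC3)nc(N)c2cc1OC`: 15000 nM
Compound 2, `COc1ccc(S(=O)(=O)N2CCN(c3nc(N)c4cc(OC)c(OC)cc4n3)CC2)cc1`: 39000 nM
Compound 3, `COc1cc2nc(N3CCN(S(=O)(=O)c4ccc(C(=O)O)cc4)CC3)nc(N)c2cc1OC`: 53000 nM

These three compounds share one core and differ only in the group carried on the phenyl ring of the sulfonamide. All were tested in a functional assay on PC-3 cells (Homo sapiens) for inhibition; on this read-out higher numbers stand for weaker inhibition and lower numbers for stronger inhibition. Compound 3 shows the highest number of the three, but its gap to compound 2 is small: a 1.4-fold higher number from compound 2 to compound 3 (0.13 log units; within the scatter), which lies within the scatter. Its gap to compound 1 is larger: a 3.5-fold higher number from compound 1 to compound 3 (0.55 log units; beyond the scatter), beyond the scatter. The third measured step is a 2.6-fold higher number from compound 1 to compound 2 (0.41 log units; beyond the scatter).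

Compound 4, `COc1cc2nc(N3CCN(S(=O)(=O)c4cc(C(=O)O)c(Cl)cc4Cl)CC3)nc(N)c2cc1OC`, is the next compound to be measured. It differs from compound 3 as follows: 5-carboxy-2,4-dichlorophenyl in place of 4-carboxyphenyl on a sulfonyl sulfur. The measured steps all exchange one group on the phenyl ring for another, and none of them adds chlorine beside a carboxy group, so they bear on this change only loosely. They show that the carboxy group and the methoxy group give the higher numbers, while iodo in compound 1 gives the lowest. Because compound 1 gives 15000 nM, a halogen on this ring does not seem to hurt, and a modest lowering of the number is the expectation here. Compound 4 is therefore expected to give 35000 nM, between 10000 nM and 120000 nM. This estimate means a step of a 1.5-fold lower number from compound 3 to compound 4 (0.18 log units; within the scatter).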

Compound 4, half-maximal inhibitory concentration: 52000 nM
The estimate for compound 4 lay 1.5-fold (0.17 log units) below the measured number; measured number inside the range.
By their numbers in this assay, from the lowest: compound 1; then compounds 2, 4 and 3 (each within the scatter of the next).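

In this assay, putting 5-carboxy-2,4-dichlorophenyl in place of 4-carboxyphenyl on a sulfonyl sulfur gives a 1.0-fold lower number from compound 3 to compound 4 (0.01 log units; within the scatter), so two added chlorines and a carboxy group at a different ring position leave no readable difference. The comparison with the methoxy compound is also within the scatter, at a 1.3-fold higher number from compound 2 to compound 4 (0.12 log units; within the scatter), whereas the iodo compound remains apart, at a 3.5-fold higher number from compound 1 to compound 4 (0.54 log units; beyond the scatter), so carrying halogen on this ring did not by itself bring compound 4 close to compound 1. No measurement shown here explains this result.

Because the chlorines and the shifted carboxy group enter together, the compounds shown cannot separate what each contributes, and a plain 2,4-dichlorophenyl group would be needed to show how the chlorines behave without the carboxy group. From the compounds shown here alone, it also remains open whether an amine or a primary amide in place of the carboxy group on the dichlorophenyl ring would give a number closer to that of compound 1.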